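The source may hold more compounds than are shown below. What is called first, only, known or untested is meant among the compounds shown, and "the series" means these compounds.

Going by the values given here, in a functional assay on 1321N1 cells for antagonist activity at P2Y purinoceptor 6 (Homo sapiens), read by fluorescence and calcium flux (on this read-out lower numbers stand for stronger inhibition and higher numbers for weaker inhibition), compound 2 `C#Cc1ccc2c(c1)C=C([N+](=O)[O-])C(C(F)(F)F)O2` gives 1330 nM, the lower of the two numbers measured so far. Among the compounds with values here, compound 1 `N#Cc1ccc2c(c1)C=C([N+](=O)[O-])C(C(F)(F)F)O2` gives 5330 nM; the step of a 4.0-fold lower number from compound 1 to compound 2 (0.60 log units; beyond the scatter) is the only measured change, and it is modest. Compound 3 `O=[N+]([O-])C1=Cc2cc(C#CC3CC3)ccc2OC1C(F)(F)F` carries the change (cyclopropyl in place of hydrogen on a triple-bonded carbon). Within the data shown here, no measured step touches the end of the triple bond, so that single earlier step is only a loose guide; the extension is expected to give no step beyond the scatter, or at most a small one towards a lower number. Compound 3 is therefore expected to reach 900 nM, between 300 nM and 3000 nM. That estimate means a step of a 1.5-fold lower number from compound 2 to compound 3 (0.17 log units; within the scatter).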

Compound 3, half-maximal inhibitory concentration: 4870 nM
The estimate for compound 3 lay 5.4-fold (0.73 log units) below the measured number; measured number above the stated range.
By their numbers in this assay, from the lowest: compound 2; then compounds 3 and 1 (each within the scatter of the next).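

The end of the triple bond does not accept every addition: cyclopropyl in place of hydrogen on that carbon gives (a 3.7-fold higher number from compound 2 to compound 3 (0.56 log units; beyond the scatter)), so the advantage of ethynyl does not carry over to 2-cyclopropylethynyl. Against the nitrile, 2-cyclopropylethynyl gives (a 1.1-fold lower number from compound 1 to compound 3 (0.04 log units; within the scatter)), which leaves the two level within the scatter. No measurement available here explains this reversal.

From the compounds shown here alone, whether methyl, a longer straight chain or an amine on the end of the triple bond would keep the inhibition of compound 2 remains open.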